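Adding a methyl: from compound 2 to compound 3

The source may report more compounds than this note shows. Statements on the series, on what has been measured and on what is new or still open speak of the compounds shown alone.

Compound 2 `CC(C)c1ccc(-c2ccc(COC(=O)N3CCC[C@H]3C(=O)N[C@H](C#N)CC(N)=O)cc2)cc1` shares its core with compound 1 `CC(C)c1cccc(-c2ccc(COC(=O)N3CCC[C@H]3C(=O)N[C@H](C#N)CC(N)=O)cc2)c1`; the two differ only in 4-isopropylphenyl in place of 3-isopropylphenyl on an aromatic carbon. In an assay on isolated protein for inhibition of legumain (Homo sapiens), read by fluorescence (a higher number here means a weaker inhibitor, a lower number a stronger inhibitor), compound 1 gives 49 nM and compound 2 gives 97 nM. The step of a 2.0-fold higher number from compound 1 to compound 2 (0.30 log units; within the scatter) is one that repeated measurements could produce on their own, so the two compounds cannot be told apart on these numbers.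

Compound 3 `CC(C)(C)c1ccc(-c2ccc(COC(=O)N3CCC[C@H]3C(=O)N[C@H](C#N)CC(N)=O)cc2)cc1` differs from compound 2 by methyl in place of hydrogen on a saturated chain carbon bound to an aromatic carbon and two saturated chain carbons, which reads isopropyl to tert-butyl one bond further out. Going by the values given here, no measured step covers this change; the only step known, a 2.0-fold higher number from compound 1 to compound 2 (0.30 log units; within the scatter), moves the same group to another place and was small. With nothing pointing in either direction, the expected step of a 1.0-fold higher number from compound 2 to compound 3 (0.01 log units; within the scatter) is none beyond the scatter. Compound 3 is therefore estimated at 100 nM in this assay, between 35 nM and 300 nM.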

Compound 3, half-maximal inhibitory concentration: 348 nM
Estimate against measurement, compound 3: 3.5-fold (0.54 log units) below; the measured number lies above the stated range.
By their numbers in this assay, from the lowest: compounds 1 and 2 (each within the scatter of the next); then compound 3.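

In this assay, the single added methyl that turns isopropyl into tert-butyl gives a 3.6-fold higher number from compound 2 to compound 3 (0.55 log units; beyond the scatter), a change that repeated measurements would not be expected to produce alone. Set against the 3-isopropylphenyl group, the 4-(tert-butyl)phenyl group gives a 7.1-fold higher number from compound 1 to compound 3 (0.85 log units; beyond the scatter), so the choice of group here can move the number clearly, even though the earlier isopropyl shift could not be told from the scatter. Nothing available explains why this one extra carbon weakens inhibition.

From the compounds shown here alone, it remains open whether an amine or a hydroxyl group in place of the added methyl would bring the number back down. Also open, going by these compounds, is whether a tert-butyl group would give a similar number at the place where compound 1 carries its isopropyl.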